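From Ethoxy to 1-Methylpiperidin-3-yl in Compound 4

A few compounds are considered here, and "the series" means these few. Any claim that something is new, unique, unknown or untested is made for them only; others in the source may bear on it.

In a functional assay on a cell-free system (plasma, Homo sapiens) for inhibition, with Plasma (Rattus norvegicus) as the target (a higher number here means a weaker inhibitor, a lower number a stronger inhibitor), compound 3 `CCOCOc1ccc2c(N3CCNCC3)cc(=O)oc2c1C` gives 1800 nM. This lies within the scatter of compound 2 `COCOc1ccc2c(N3CCNCC3)cc(=O)oc2c1C` at 2300 nM and of compound 1 `COc1c(C)cnc(COc2ccc3c(N4CCNCC4)cc(=O)oc3c2C)c1C` at 3300 nM. Compound 4 `Cc1c(OCC2CCCN(C)C2)ccc2c(N3CCNCC3)cc(=O)oc12` differs from compound 3 as follows: 1-methylpiperidin-3-yl in place of ethoxy on a saturated chain carbon bound to an oxygen on an aromatic ring. The closest evidence is a 1.8-fold lower number from compound 1 to compound 3 (0.26 log units; within the scatter), where ethoxy replaces a ring-bearing group at this same place. The steps of a 1.4-fold lower number from compound 1 to compound 2 (0.16 log units; within the scatter) and a 1.3-fold lower number from compound 2 to compound 3 (0.11 log units; within the scatter) are also small. Among the compounds with values here, all three lie within the scatter, yet no measured compound carries a non-aromatic ring here, so the new group remains untested. In this assay, no step beyond the scatter is expected, and the estimated change is a 1.4-fold higher number from compound 3 to compound 4 (0.14 log units; within the scatter). For compound 4 the estimate is 2500 nM, with an expected range of 800 nM to 7000 nM.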

Compound 4, half-maximal inhibitory concentration: 4700 nM
Compound 4: middle estimate off by 1.9-fold (0.27 log units), on the low side; measured number inside the range.
By their numbers in this assay, from the lowest: compounds 3, 2, 1 and 4 (each within the scatter of the next, the first and the last beyond it).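

In this assay, this position now shows steps beyond the scatter: 1-methylpiperidin-3-yl gives a modest rise in place of ethoxy (a 2.6-fold higher number from compound 3 to compound 4 (0.42 log units; beyond the scatter)) and in place of methoxy (a 2.0-fold higher number from compound 2 to compound 4 (0.31 log units; beyond the scatter)). In place of 4-methoxy-3,5-dimethylpyridin-2-yl, it stays within the scatter (a 1.4-fold higher number from compound 1 to compound 4 (0.15 log units; within the scatter)), so these two ring-bearing groups cannot be told apart here. Nothing available explains why the ring-bearing groups and the small ethers differ in this way.

From the compounds shown here alone, whether a plain piperidin-3-yl without its methyl, or an open-chain dimethylamino group, would read like compound 4 or like compound 3 stays open.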